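Swapping nitro for methoxy: an expected cytotoxicity estimate

A few compounds are considered here, and "the series" means these few. Any claim that something is new, unique, unknown or untested is made for them only; others in the source may bear on it.

Compound 1 `CNC(=O)c1cc(Oc2ccc(C3=NNC(c4cccc(Br)c4)C3)cc2)ccn1`: 1960 nM
Compound 2 `CNC(=O)c1cc(Oc2ccc(C3=NNC(c4ccc([N+](=O)[O-])cc4)C3)cc2)ccn1`: "not determined" (no result reported)

In a functional assay on MCF7 cells (Homo sapiens) for cytotoxicity, read by MTT assay, with a stated time of 72 h (on this read-out lower numbers stand for stronger inhibition and higher numbers for weaker inhibition), compound 1 gives 1960 nM. In this assay compound 2 gives "not determined" (no result reported), so it has no single number and stands nowhere on the numbers shown. Compound 3, `CNC(=O)c1cc(Oc2ccc(C3=NNC(c4ccc(OC)cc4)C3)cc2)ccn1`, differs from compound 2 by methoxy in place of nitro on an aromatic carbon. Among the measured compounds shown here, with no measured step for this change, the shift from compound 2 to compound 3 in this assay is expected to be small, in no fixed direction, and not beyond the usual scatter. Compound 3 is therefore expected to give about 2500 nM in this assay, within a range from 600 nM to 10000 nM. This expectation rests on compound 1, which gives 1960 nM in this assay.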

Compound 3, half-maximal inhibitory concentration: 11000 nM
The estimate for compound 3 lay 4.4-fold (0.64 log units) below the measured number; measured number outside the range, above it.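

With 4-methoxyphenyl in place of 3-bromophenyl on the saturated ring carbon, the series shows a 5.6-fold higher number from compound 1 to compound 3 (0.75 log units; beyond the scatter) in this assay and so this position does not tolerate every aryl group equally. The step from nitro to methoxy itself cannot be read, as compound 2 has no number. Nothing available gives a reason for the shift.

Compounds 1 and 3 leave open whether the change of substituent or its place on the phenyl ring drives the difference. Going by these compounds, how an amine or a carboxylic acid in place of the methoxy would read also remains open.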